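The source may hold more compounds than are shown below. What is called first, only, known or untested is meant among the compounds shown, and "the series" means these compounds.

Measured so far:
- compound 1, `CCC[C@H](C(=O)NC(N)=O)C(C)C`: 18 mg/kg
- compound 2, `CCC[C@H](C(N)=O)C(C)C`: 63 mg/kg

In a functional assay on the whole organism (strain Sprague-Dawley) with Rattus norvegicus as the target, in the maximal electroshock model (on this read-out lower numbers stand for an effect already at smaller amounts and higher numbers for an effect only at larger amounts of compound), compound 1 gives 18 mg/kg, the lowest of the two numbers at hand. Compound 2, which carries hydrogen in place of carbamoyl on an amide-type nitrogen, gives 63 mg/kg in this assay, and the step is a 3.5-fold higher number from compound 1 to compound 2 (0.54 log units; beyond the scatter).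

Compound 3, `CCC[C@@H](C(=O)NC(N)=O)C(C)C`, has not yet been measured in this assay. It relates to compound 1 as follows: the two compounds have the same atoms and bonds and differ only in configuration as drawn: 1 of 1 stereo elements differ; a stereocentre at a saturated chain carbon is drawn S in compound 1 and R in compound 3. The two compounds share every atom and bond; only the spatial arrangement at one saturated chain carbon is drawn differently.

Neither measured step bears on this change. Going by the values given here, the single step at hand, from compound 1 to compound 2, concerns an exchange of groups on the nitrogen, not a change of configuration, and so it gives no guide to how a mirror-image arrangement at the chain carbon would shift the number. With nothing to lean on, the expected step in this assay is a 1.7-fold higher number from compound 1 to compound 3 (0.22 log units; within the scatter), with a wide range on either side to reflect that uncertainty. The estimate for compound 3 in this assay is therefore 30 mg/kg, between 12 mg/kg and 80 mg/kg.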

Compound 3, dose for half-maximal effect: 36 mg/kg
For compound 3 the middle estimate is 1.2-fold (0.08 log units) below the measured one; the range from low to high includes it.
By their numbers in this assay, from the lowest: compounds 1, 3 and 2 (each within the scatter of the next, the first and the last beyond it).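

Turning the saturated chain carbon from S to R gives, in this assay, a 2.0-fold higher number from compound 1 to compound 3 (0.30 log units; within the scatter), so as far as this read-out can tell, the position accepts either drawn arrangement. The change on the nitrogen gave a 3.5-fold higher number from compound 1 to compound 2 (0.54 log units; beyond the scatter), whereas the new step does not stand clear of the normal spread of repeated measurements, so these two numbers support no claim that one arrangement is preferred. The comparison is a clean one, and any real gap between the two numbers could come from only one structural source, because of this: the fact that compounds 1 and 3 differ only in the configuration as drawn

On these data alone, it remains open whether the same tolerance of either arrangement would hold in the plain amide of compound 2, where the carbamoyl group is absent. It is also unknown how a carboxylic acid in place of the carbamoyl-bearing amide, or a longer chain on the same carbon, would shift the number, and whether the two arrangements would then still lie this close together.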